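Swapping the aryl group on a sulfonamide nitrogen

This account rests on a few compounds, and the source may have more. Where it says the series, first, only, none or still open, it means among the compounds named here.

Measured compounds:
compound 1 `O=C(/C=C/c1cccnc1)NCCCCCc1cccc(S(=O)(=O)Nc2ccccc2)c1` gives 140 nM in a functional assay on DU-145 cells (Homo sapiens) for inhibition, read by CCK-8 assay, with a stated time of 72 h; on this read-out lower numbers stand for stronger inhibition and higher numbers for weaker inhibition
compound 2 `Cc1ccccc1NS(=O)(=O)c1cccc(CCCCCCNC(=O)/C=C/c2cccnc2)c1` gives 2.9 nM in this assay

Among the two measured compounds, compound 2 stands with the lowest number, and so the stronger inhibition. Its nearest neighbour on the numbers is compound 1, whose value lies well beyond the usual scatter of repeated measurements. Compound 1 and compound 2 differ in more than one place, so their gap cannot be tied to a single structural change; the two values simply show that compound 2 inhibits far more strongly.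

Compound 3 `O=C(/C=C/c1cccnc1)NCCCCCCc1cccc(S(=O)(=O)Nc2ccc(C(F)(F)F)cc2)c1` has not yet been measured in this assay. It keeps everything of compound 2 except one group: 4-(trifluoromethyl)phenyl in place of 2-methylphenyl on a sulfonamide nitrogen. For the measured compounds named here, nothing among the measured compounds shows what this particular swap on the sulfonamide nitrogen does, so the direction of the step is open. The expectation, held loosely, is that compound 3 lands somewhat weaker than compound 2, a step of a 5.2-fold higher number from compound 2 to compound 3 (0.71 log units; beyond the scatter), since only compound 2 with its 2-methylphenyl has reached such a low number. Compound 3 is thus estimated at 15 nM, within a range from 3 nM to 80 nM.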

Compound 3, half-maximal inhibitory concentration: 1410 nM
The estimate for compound 3 lay 94-fold (1.97 log units) below the measured number; the measured number lies above the stated range.
By their numbers in this assay, from the lowest: compound 2; then compound 1; then compound 3.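

In this assay, the group on the sulfonamide nitrogen proves far from a minor detail: with the rest of the molecule unchanged, 4-(trifluoromethyl)phenyl in place of 2-methylphenyl gives a 490-fold higher number from compound 2 to compound 3 (2.69 log units; beyond the scatter), a large loss of inhibition. This is the first pair shown that differs in only one place, so this gap, unlike the one between the first two compounds, can be tied to a single structural change. That change still alters two things at once, the substituent on the ring and its numbered place, and nothing measured here explains why the step is so large.

The compounds shown leave open whether the loss follows the trifluoromethyl group or the move from the 2-place to the 4-place, a question that 4-methylphenyl and 2-(trifluoromethyl)phenyl on the same nitrogen could help separate. Also open, going by these compounds, is how an unsubstituted phenyl, a 2-chlorophenyl or a 2-methoxyphenyl group would fare at this position with everything else in compound 2 kept the same.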